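Lengthening the Carbamate Chain of a Potent Inhibitor

This account rests on a few compounds, and the source may have more. Where it says the series, first, only, none or still open, it means among the compounds named here.

Of the compounds shown here, three have been measured in an assay on cell membranes (strain Wistar) for inhibition of Fatty-acid amide hydrolase 1 (Rattus norvegicus), read by scintillation counting; a higher number here means a weaker inhibitor, a lower number a stronger inhibitor. Compound 2 `CCCCNC(=O)Oc1cccc(-c2csnn2)c1` gives 6.9 nM, the lowest number of the three. Compound 3 `CCCCCCCCCCCCNC(=O)Oc1ccccc1-c1csnn1` gives 50 nM, and compound 1 `CCCCNC(=O)Oc1ccc(C2=NCCO2)cc1` gives 120 nM; both gaps to compound 2 lie beyond the scatter, so compound 2 is the strongest inhibitor measured here.

Compound 4 `CCCCCCCCCCCCNC(=O)Oc1cccc(-c2csnn2)c1` is compound 2 with one change: octyl in place of hydrogen on a saturated chain carbon, four bonds along the chain from an amide-type nitrogen. For the measured compounds named here, no measured pair shows this change on its own, so the size of its effect is not known from the data. Compound 4 is expected to be a somewhat weaker inhibitor than compound 2, with an estimated step of a 2.2-fold higher number from compound 2 to compound 4 (0.34 log units; beyond the scatter), and its value in this assay is estimated at 15 nM, within a range from 3 nM to 80 nM.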

Compound 4, half-maximal inhibitory concentration: 0.24 nM
Estimate against measurement, compound 4: 63-fold (1.80 log units) above, and the stated range ends above it.
By their numbers in this assay, from the lowest: compound 4; then compound 2; then compound 3; then compound 1.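

In this assay, octyl in place of hydrogen on a saturated chain carbon, four bonds along the chain from an amide-type nitrogen, gives a 29-fold lower number from compound 2 to compound 4 (1.46 log units; beyond the scatter), a large step towards stronger inhibition. This chain position therefore accepts far more than a hydrogen, and here the added carbons strengthen inhibition instead of weakening it. Nothing at hand explains the size of this step.

As far as these compounds go, only these two chain lengths can be compared on this core, so the trend between and beyond them stays open. From the compounds shown here alone, whether a hexyl group, a longer chain or a chain ending in a carboxylic acid would do better or worse remains unknown.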